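This account rests on a few compounds, and the source may have more. Where it says the series, first, only, none or still open, it means among the compounds named here.

In a functional assay on NAMALVA cells (Homo sapiens) for cytotoxicity, read by trypan blue exclusion, with a stated time of 96 h (on this read-out lower numbers stand for stronger inhibition of growth and higher numbers for weaker inhibition of growth), compound 2 `COc1cc(OC)c(/C=C/S(=O)(=O)Nc2ccc(OC)c(O)c2)c(OC)c1` gives 25 nM, the lowest of the two numbers recorded. Compound 1 `COc1ccc(NS(=O)(=O)/C=C/c2c(OC)cc(OC)cc2OC)cc1` gives 100 nM in this assay, and the step of a 4.0-fold lower number from compound 1 to compound 2 (0.60 log units; beyond the scatter) is the only measured one. Compound 3 `COc1cc(OC)c(/C=C/S(=O)(=O)Nc2ccc(OC)c(N)c2)c(OC)c1` differs from compound 2 by amino in place of hydroxy on an aromatic carbon. Among the measured compounds shown here, no measured step bears directly on replacing hydroxy with amino; the step of a 4.0-fold lower number from compound 1 to compound 2 (0.60 log units; beyond the scatter) shows only that a group at this place is tolerated. Compound 3 is therefore expected to stay close to compound 2, with the step of a 1.6-fold higher number from compound 2 to compound 3 (0.20 log units; within the scatter) likely within the scatter. The estimate for compound 3 is 40 nM, ranging from 15 nM to 120 nM.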

Compound 3, concentration for 50% growth inhibition: 8 nM
For compound 3 the middle estimate is 5.0-fold (0.70 log units) above the measured one; the whole stated range lies above it.
By their numbers in this assay, from the lowest: compound 3; then compound 2; then compound 1.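

The exchange of hydroxy for amino on this aromatic carbon is not neutral: in this assay it gives a 3.1-fold lower number from compound 2 to compound 3 (0.49 log units; beyond the scatter), although the two groups have the same counts of heavy atoms, hydrogen-bond donors and acceptors. Against hydrogen at this place, amino gives a 13-fold lower number from compound 1 to compound 3 (1.10 log units; beyond the scatter), so the identity of the group matters here, not merely the presence of one. Nothing available explains this difference between amino and hydroxy. As far as these compounds go, whether a methylamine, an acetamide or a fluorine at this place would match amino remains open.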